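The source may report more compounds than this note shows. Statements on the series, on what has been measured and on what is new or still open speak of the compounds shown alone.

In an ADME assay on HEL cells (Homo sapiens), read by cell counting, with a stated time of 3 days (on this read-out lower numbers stand for higher toxicity in this test and higher numbers for lower toxicity in this test), compound 1 `O=c1[nH]c(=O)n([C@H]2C[C@H](O)[C@@H](CO)O2)cc1C#CC#Cc1ccccc1` gives 100000 nM. Compound 2 `CCCc1ccc(C#CC#Cc2cn([C@H]3C[C@H](O)[C@@H](CO)O3)c(=O)[nH]c2=O)cc1` gives 52000 nM, and compound 3 `CCCCCCc1ccc(C#CC#Cc2cn([C@H]3C[C@H](O)[C@@H](CO)O3)c(=O)[nH]c2=O)cc1` gives 35000 nM, so compound 1 stands clear of compound 3 only. Compound 4 `COc1cc(C#CC#Cc2cn([C@H]3C[C@H](O)[C@@H](CO)O3)c(=O)[nH]c2=O)cc(OC)c1` differs from compound 1 as follows: 3,5-dimethoxyphenyl in place of phenyl on a triple-bonded carbon. That is, 3,5-dimethoxyphenyl stands in place of phenyl on a triple-bonded carbon. The nearest guides are a 1.9-fold lower number from compound 1 to compound 2 (0.28 log units; within the scatter) and a 2.9-fold lower number from compound 1 to compound 3 (0.46 log units; beyond the scatter), both with a chain placed on an aromatic carbon. Neither adds a methoxy group, so they guide only loosely, and they suggest a small move to a lower number at most. The expected step is a 1.4-fold lower number from compound 1 to compound 4 (0.15 log units; within the scatter), none beyond the scatter. Compound 4 is estimated at 70000 nM, with an expected range of 32000 nM to 150000 nM.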

Compound 4, half-maximal cytotoxic concentration: > 100000 nM
Compound 4 gave a limit, no number; the forecaster's own chance of this, stated with the estimate: 25%; middle value at least 1.4-fold (0.15 log units) away from the limit.
By their numbers in this assay, from the lowest: compounds 3, 2 and 1 (each within the scatter of the next, the first and the last beyond it).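

Compound 4 gives a limit, > 100000 nM, not a number. As far as these compounds go, the step is a number no lower from compound 1 to compound 4 (the limit leaves the size open), because its size stays open at this limit: the limit of > 100000 nM in this assay, at which 1 of the 4 values shown sits. Against the chain-bearing compound 2, the step is an at least 1.9-fold higher number from compound 2 to compound 4 (0.28 log units; that floor lies within the scatter), so 3,5-dimethoxyphenyl on this triple-bonded carbon gives no sign of the lower number seen with hexyl, a 2.9-fold lower number from compound 1 to compound 3 (0.46 log units; beyond the scatter).

The compounds shown leave open how a single methoxy group would read here. They also leave open how an amine or a carboxylic acid on the phenyl group would read.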